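Acetoxy Substitution on a Lactone Ring: Expected Cytotoxicity

The compounds below may be only part of what the source reports. "The series", "measured", "known", "first", "only" and "open" are said of these compounds alone.

Measured compounds:
compound 1, `CC(=O)O[C@@H](C)[C@@H](/C=C/[C@@H]1O[C@@H]1[C@H]1CC=CC(=O)O1)OC(C)=O`, 4.7 ug/mL
compound 2, `CCCC[C@H](OC(C)=O)[C@@H](OC(C)=O)[C@H](OC(C)=O)[C@H]1CC=CC(=O)O1`, 8.7 ug/mL

In a functional assay on ZR-75-1 cells (Homo sapiens) for cytotoxicity, read by sulforhodamine B assay, with a stated time of 72 h (on this read-out higher numbers stand for an effect only at larger amounts of compound and lower numbers for an effect already at smaller amounts), compound 2 gives 8.7 ug/mL, the highest of the two numbers recorded so far. Its nearest neighbour is compound 1, which in this assay gives 4.7 ug/mL; the gap between these two values lies within the scatter of repeated measurements, so no order between them can be claimed.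

Compound 3, `CCCC[C@H](OC(C)=O)[C@@H](OC(C)=O)[C@H](OC(C)=O)[C@@H]1OC(=O)C=C[C@@H]1OC(C)=O`, has not yet been measured. It differs from compound 2 in one place: acetoxy in place of hydrogen on a saturated ring carbon, on a saturated ring carbon of the six-membered non-aromatic ring, two ring bonds from the ring oxygen.

Within the data shown here, no step between measured compounds is available to guide the expectation. Compound 3 is therefore expected to lie close to compound 2, with a step of a 1.1-fold lower number from compound 2 to compound 3 (0.04 log units; within the scatter) that is not expected to exceed the scatter in either direction. The estimate for compound 3 in this assay is 8 ug/mL, within a range from 3 ug/mL to 20 ug/mL.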

Compound 3, concentration for half-maximal effect: 7.8 ug/mL
The estimate for compound 3 lay 1.0-fold (0.01 log units) above the measured number; measured number inside the range.
By their numbers in this assay, from the lowest: compounds 1, 3 and 2 (each within the scatter of the next).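

In this assay, acetoxy in place of hydrogen on a saturated ring carbon, two ring bonds from the ring oxygen, comes with a 1.1-fold lower number from compound 2 to compound 3 (0.05 log units; within the scatter). Among these compounds, this is the first comparison here between compounds that differ in one place, and it shows that this ring carbon can carry an acetoxy group without a change in the number that stands out from the scatter. No measurement at hand gives a reason for this outcome.

From the compounds shown here alone, whether a different group on this ring carbon, such as an amine, a carboxylic acid or a longer chain, would also stay within the scatter remains open. The compounds shown also leave open whether the same acetoxy group would give a similar step on the core of compound 1.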